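Thiophene-bearing series: acyl variation at the carbonyl carbon

The source may hold more compounds than are shown below. What is called first, only, known or untested is meant among the compounds shown, and "the series" means these compounds.

Within the data shown here, the three measured members share one core and differ only in the group on the carbonyl carbon. Compound 1 `CC1=C(C(=O)C2CC2)C(c2ccsc2)NC(=O)N1` carries cyclopropyl there, compound 2 `CCCC(=O)C1=C(C)NC(=O)NC1c1ccsc1` propyl and compound 3 `CCN(CC)C(=O)C1=C(C)NC(=O)NC1c1ccsc1` diethylamino. In an assay on membranes from HEK293 cells for displacement of a labelled ligand from adenosine receptor A2b (Homo sapiens), read by scintillation counting, with a stated time of 30 min, tested at 1 uM (on this read-out lower numbers stand for less inhibition and higher numbers for more inhibition at the one concentration tested (going by the name of the read-out)), compound 1 gives 1%, compound 2 gives 9% and compound 3 gives 11%. The number for compound 3 is the top one of the three, yet its gaps to the others are small: the change a number 10 percentage points higher from compound 1 to compound 3 (within the scatter) and the change a number 2 percentage points higher from compound 2 to compound 3 (within the scatter) both sit inside the scatter, as does a number 8 percentage points higher from compound 1 to compound 2 (within the scatter). Nothing among these three separates one acyl group from another.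

Compound 4 `CCSC(=O)C1=C(C)NC(=O)NC1c1ccsc1` continues the exchange at the same position: ethylsulfanyl in place of diethylamino on a carbonyl carbon. The three measured steps all bear on it, since each also swaps one group on that carbonyl carbon, and none of them moved the read-out beyond the scatter. There is no basis to expect ethylsulfanyl to behave differently; the step of a number 3 percentage points lower from compound 3 to compound 4 (within the scatter) is expected to stay within the scatter. Compound 4 is therefore estimated at 8% in this assay, with a range from 0% to 20%.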

Compound 4, a percentage reported as inhibition, at one concentration (the size of the read-out at that concentration, not a potency): 17%
Estimate against measurement, compound 4: 9 percentage points below; the range from low to high includes it.
By their numbers in this assay, from the lowest: compounds 1, 2, 3 and 4 (each within the scatter of the next, the first and the last beyond it).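

Among these compounds, at the carbonyl carbon, the group exchange in this assay now gives its first separation, the change a number 16 percentage points higher from compound 1 to compound 4 (beyond the scatter) being the only step printed as beyond the scatter. That separation holds against cyclopropyl alone, as the change a number 6 percentage points higher from compound 3 to compound 4 (within the scatter) and the change a number 8 percentage points higher from compound 2 to compound 4 (within the scatter) both remain within the scatter, so ethylsulfanyl is not set apart from diethylamino or propyl, and compounds 2 and 3 do not separate from compound 1 either. No measurement at hand accounts for the separation from compound 1.

Open, from the compounds shown here alone, is whether the separation belongs to ethylsulfanyl itself: ethoxy or methylsulfanyl on the same carbonyl carbon could show whether compound 4 stands apart from cyclopropyl through its sulfur or through its chain, and a longer chain such as butylsulfanyl could show whether the number moves further. Also open, going by these compounds, is whether any of these differences would hold as a potency, since the read-out here gives only the size of inhibition at one concentration.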